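Acyl variation on the shared core: expectation for compound 4

A few compounds are considered here, and "the series" means these few. Any claim that something is new, unique, unknown or untested is made for them only; others in the source may bear on it.

Compound 3 `CCCCCCCCCCCCCCNC(=O)[C@@H](NC(=O)/C=C/c1ccccc1)[C@@H](C)O` carries the 2-phenylethenyl carbonyl on the shared core; in a functional assay on SiHa cells (Homo sapiens) for cytotoxicity, read by MTT assay, with a stated time of 48 h (a lower number here means a stronger inhibitor, a higher number a weaker inhibitor), compound 3 gives 35800 nM, the second highest of the three numbers measured. Compound 2 `CCCCCCCCCCCCCCNC(=O)[C@@H](NC(=O)c1nccc2ccccc12)[C@@H](C)O` gives 21600 nM and compound 1 `CCCCCCCCCCCCCCNC(=O)[C@@H](NC(=O)c1ccco1)[C@@H](C)O` gives 127000 nM. The steps read a 3.5-fold lower number from compound 1 to compound 3 (0.55 log units; beyond the scatter) and a 1.7-fold higher number from compound 2 to compound 3 (0.22 log units; within the scatter); both concern the acyl group, and the largest move, a 5.9-fold lower number from compound 1 to compound 2 (0.77 log units; beyond the scatter), is the departure from furan-2-yl. Compound 4 `C/C=C/C=C/C(=O)N[C@H](C(=O)NCCCCCCCCCCCCCC)[C@@H](C)O` differs by prop-1-en-1-yl in place of phenyl on a double-bonded chain carbon bound to a double-bonded chain carbon. For the measured compounds named here, no measured step removes an aromatic ring from the acyl group, so the direction rests on compound 1, whose 127000 nM stands at the weak end. The expected step is a 1.8-fold higher number from compound 3 to compound 4 (0.26 log units; within the scatter), a modest rise in the number in this assay. Compound 4 is estimated at 65000 nM, within 25000 nM to 170000 nM.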

Compound 4, half-maximal inhibitory concentration: > 200000 nM
Compound 4 ended at the assay's limit; the forecaster's own chance of this, stated with the estimate: 10%; middle value at least 3.0-fold (0.48 log units) away from the limit.
By their numbers in this assay, from the lowest: compounds 2 and 3 (each within the scatter of the next); then compound 1. At a limit, above all of these: compound 4.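

In this assay compound 4 gives > 200000 nM, a limit of the assay and not a number: the limit of > 200000 nM in this assay, at which 1 of the 4 values shown sits. Prop-1-en-1-yl in place of phenyl on a double-bonded chain carbon bound to a double-bonded chain carbon, which gives the only acyl group shown without an aromatic ring, is a step beyond the scatter: an at least 5.5-fold higher number from compound 3 to compound 4 (0.74 log units; beyond the scatter), and likewise an at least 9.2-fold higher number from compound 2 to compound 4 (0.96 log units; beyond the scatter). Against the furan-2-yl acyl group only a floor stands, an at least 1.5-fold higher number from compound 1 to compound 4 (0.19 log units; that floor lies within the scatter), so no order follows there.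

Still open, on these data alone, is whether the loss tracks the missing aromatic ring or the diene itself. A saturated pentyl acyl group, or a phenyl ring carrying an amine, would help separate these readings.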